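The source may hold more compounds than are shown below. What is called first, only, known or untested is meant among the compounds shown, and "the series" means these compounds.

Going by the values given here, compound 2 `CC(=NNC(=S)Nc1ccccc1I)c1ccccn1` holds the highest of the two numbers so far measured: in a functional assay on U-87MG ATCC cells (Homo sapiens) for cytotoxicity, read by MTT assay, with a stated time of 48 h (a higher number here means a weaker inhibitor, a lower number a stronger inhibitor), compound 2 gives 6.1 nM. Its nearest neighbour is compound 1 `C/C(=N\NC(=S)Nc1ccccc1[N+](=O)[O-])c1ccccn1`, which in this assay gives 4.3 nM, a gap within the usual scatter, so the two are not separable. Compound 3 `C/C(=N\NC(=S)Nc1ccccc1I)c1ccccn1` differs from compound 2 only in how it is drawn: the two compounds have the same atoms and bonds; at least one stereo element is drawn with a configuration in one of them and without one in the other: 1 of 1 stereo elements differ; a double bond is drawn without a configuration in compound 2 and E in compound 3. Since the atoms and bonds are the same, no step beyond the scatter is expected, the expected step being a 1.0-fold lower number from compound 2 to compound 3 (0.01 log units; within the scatter). Compound 3 is therefore estimated at 6 nM, expected to fall between 2.5 nM and 15 nM.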

Compound 3, half-maximal inhibitory concentration: 6.1 nM
The estimate for compound 3 lay 1.0-fold (0.01 log units) below the measured number, and the stated range covers the measured number.
By their numbers in this assay, from the lowest: compounds 1, 2 and 3 (each within the scatter of the next).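

In this assay the result is no change at the digits printed from compound 2 to compound 3 (within the scatter), so the entries for compound 2 and compound 3 read as a single result, and the only distinction between them lies in the drawing: the fact that one of compounds 2 and 3 is drawn with a defined configuration and the other without, at the place where they differ. Compound 1 and compound 3 are drawn alike at the double bond, which gives a clean comparison of iodo in place of nitro on the aromatic carbon: a 1.4-fold higher number from compound 1 to compound 3 (0.15 log units; within the scatter), so the two groups are not separated here. Still open, on these data alone, is how the Z double bond would read, and whether an amine or a carboxylic acid on that aromatic carbon would keep the number in this range.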